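Prenylated coumarin amides: a methyl on the side chain

The compounds below may be only part of what the source reports. "The series", "measured", "known", "first", "only" and "open" are said of these compounds alone.

Measured so far:
compound 1, `CCN(C)CCCOc1ccc2cc(NC(=O)c3ccc(O)c(CC=C(C)C)c3)c(=O)oc2c1C`, 730 nM
compound 2, `CC(C)=CCc1cc(C(=O)Nc2cc3ccc(OCCCN(C)C(C)C)c(C)c3oc2=O)ccc1O`, 570 nM
compound 3, `CC(C)=CCc1cc(C(=O)Nc2cc3ccc(OCCCNCc4ccccc4)c(C)c3oc2=O)ccc1O`, 470 nM

All three compounds share a core and differ only in the amine at the end of the side chain. In a functional assay on SK-BR-3 cells (Homo sapiens) for antiproliferative activity (a higher number here means a weaker inhibitor, a lower number a stronger inhibitor), compound 1 gives 730 nM. Compound 2 carries methyl in place of hydrogen on a saturated chain carbon bound to an amine nitrogen and a saturated chain carbon, and the step of a 1.3-fold lower number from compound 1 to compound 2 (0.11 log units; within the scatter) stays within the scatter. Compound 3 differs from compound 1 by benzylamino in place of ethyl(methyl)amino on a saturated chain carbon, three bonds along the chain from an oxygen on an aromatic ring, and the step of a 1.6-fold lower number from compound 1 to compound 3 (0.19 log units; within the scatter) also stays within the scatter, as does the step of a 1.2-fold lower number from compound 2 to compound 3 (0.08 log units; within the scatter). None of the three can be called stronger or weaker than another on these numbers.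

Compound 4, `CC(C)=CCc1cc(C(=O)Nc2cc3ccc(OCCCN[C@H](C)c4ccccc4)c(C)c3oc2=O)ccc1O`, has not yet been measured. It differs from compound 3 by methyl in place of hydrogen on a saturated chain carbon bound to an amine nitrogen and an aromatic carbon. For the measured compounds named here, this is the same kind of change as the one from compound 1 to compound 2, but not the same: there the carbon was bound to an amine nitrogen and a saturated chain carbon, here it is bound to an amine nitrogen and an aromatic carbon. Because the earlier step of a 1.3-fold lower number from compound 1 to compound 2 (0.11 log units; within the scatter) was within the scatter, a step of similar size is expected here. The step this estimate means, a 1.1-fold lower number from compound 3 to compound 4 (0.05 log units; within the scatter), is expected to stay within the scatter as well. Compound 4 is therefore estimated at about 420 nM, with the expected range from 200 nM to 900 nM.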

Compound 4, half-maximal inhibitory concentration: 1000 nM
The estimate for compound 4 lay 2.4-fold (0.38 log units) below the measured number, outside the stated range (above it).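

In this assay, adding the methyl on the saturated chain carbon bound to an amine nitrogen and an aromatic carbon gives a 2.1-fold higher number from compound 3 to compound 4 (0.33 log units; beyond the scatter), a modest step but one beyond the scatter, whereas the steps that reach compound 4 from the other two compounds, a 1.8-fold higher number from compound 2 to compound 4 (0.24 log units; within the scatter) and a 1.4-fold higher number from compound 1 to compound 4 (0.14 log units; within the scatter), both stay within it. Methyl in place of hydrogen therefore did not carry over as one fixed step in this series, since the same kind of change gave clearly different results in its two settings: the same change on two cores in this assay, a 1.3-fold lower number (0.11 log units; within the scatter) from compound 1 to compound 2 and a 2.1-fold higher number (0.33 log units; beyond the scatter) from compound 3 to compound 4, 2.7-fold (0.44 log units) apart, beyond the scatter of two such steps. For the compounds shown here, this rests on only two pairs, in which the methyl sits on differently bound carbons, so it shows that the earlier step was a poor guide to the later one, but it does not show what sets the gap or how the change would behave on any other amine.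

The compounds shown leave open whether the result for compound 4 belongs to its particular configuration, as the opposite configuration of the (1-phenylethyl)amino group would test. They also leave open how a methyl(benzyl)amino group or a (1-phenylpropyl)amino group would compare with compound 3 in this assay.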